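The source may report more compounds than this note shows. Statements on the series, on what has been measured and on what is new or still open speak of the compounds shown alone.

In a functional assay on SK-MEL-28 cells (Homo sapiens) for cytotoxicity, read by MTT assay (a higher number here means a weaker inhibitor, a lower number a stronger inhibitor), compound 1 `O=S(=O)(NCCNc1nccc(-c2c(-c3cccc(F)c3)nc3sccn23)n1)c1ccc(F)cc1` gives 9450 nM. Within the data shown here, only one other compound has been measured: compound 2 `O=S(=O)(NCCCNc1nccc(-c2c(-c3cccc(F)c3)nc3sccn23)n1)c1ccc(C(F)(F)F)cc1` gives 11700 nM, a number that lies within the usual scatter of the one for compound 1, so the two cannot be told apart. Compound 3 `O=S(=O)(NCCNc1nccc(-c2c(-c3cccc(F)c3)nc3sccn23)n1)c1cccc(F)c1` has not been measured. It differs from compound 1 by 3-fluorophenyl in place of 4-fluorophenyl on a sulfonyl sulfur. Among the measured compounds shown here, nothing among the measured compounds shows what this change does, and a shift of this kind is expected to stay within the scatter, with a 1.0-fold higher number from compound 1 to compound 3 (0.00 log units; within the scatter) expected to be about none. Compound 3 is estimated at 9500 nM, between 4000 nM and 22000 nM.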

Compound 3, half-maximal inhibitory concentration: 18300 nM
Compound 3: the middle estimate sits 1.9-fold (0.28 log units) below what was measured, within the range that was stated.
By their numbers in this assay, from the lowest: compounds 1, 2 and 3 (each within the scatter of the next).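

Putting 3-fluorophenyl in place of 4-fluorophenyl on a sulfonyl sulfur gives a 1.9-fold higher number from compound 1 to compound 3 (0.29 log units; within the scatter) in this assay, so the two groups cannot be told apart here. Among these compounds, the earlier compounds offered no comparison that differed in this one place, and this pair is the first to do so. Nothing measured here offers an explanation for the numbers at this position.

On these data alone, it remains open whether a plain phenyl, a methoxyphenyl or a pyridine ring on the sulfonyl sulfur would move the number beyond the scatter. As far as these compounds go, the effect of replacing the sulfonamide nitrogen's sulfonyl group with a carbonyl also remains unknown.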